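Benzyl for Benzoyl on the Ring Amine of Compound 3

This account rests on a few compounds, and the source may have more. Where it says the series, first, only, none or still open, it means among the compounds named here.

Compound 1 `N=C1S/C(=C\c2ccc(OCc3ccccc3)cc2)C(=O)N1c1ccc(Br)cc1`: 7.83%
Compound 2 `N=C1S/C(=C\c2ccc(OCc3ccccc3)cc2)C(=O)N1c1ccccn1`: 37.2%
Compound 3 `NC(=O)c1c(NC(=O)c2ccc(Cl)cc2)sc2c1CCN(C(=O)c1ccccc1)C2`: 42.5%

In an ADME assay on RAW264.7 cells (Mus musculus) for cytotoxicity, read by MTT assay, with a stated time of 48 h, tested at 50 uM (a higher number here means more inhibition at the concentration tested (going by the name of the read-out), a lower number less inhibition), compound 3 gives the highest of the three numbers; compound 2 lies within the scatter of it, while compound 1 lies far lower, beyond the scatter. Within the data shown here, the only measured step, a number 29.4 percentage points higher from compound 1 to compound 2 (beyond the scatter), sits on a different core and concerns a different change, so it does not bear on the step to compound 4 `NC(=O)c1c(NC(=O)c2ccc(Cl)cc2)sc2c1CCN(Cc1ccccc1)C2`. Compound 4 differs from compound 3 in one place: benzyl in place of benzoyl on an amine nitrogen in a ring. Among the measured compounds shown here, with no measured step of this kind, the expectation rests on compound 3 alone, at 42.5%. Compound 4 is therefore expected to show no step beyond the scatter, a number 2.5 percentage points lower from compound 3 to compound 4 (within the scatter). The estimated value for compound 4 is 40%, with a range from 20% to 60%.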

Compound 4, a percentage reported as inhibition, at one concentration (the size of the read-out at that concentration, not a potency): 11.1%
For compound 4 the middle estimate is 28.9 percentage points above the measured one; the measured number lies below the stated range.
By their numbers in this assay, from the lowest: compounds 1 and 4 (each within the scatter of the next); then compounds 2 and 3 (each within the scatter of the next).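

In this assay, the amine nitrogen in the ring proves to be a place where the choice of group matters: benzyl in place of benzoyl gives a number 31.4 percentage points lower from compound 3 to compound 4 (beyond the scatter). The change takes away the carbonyl, with its hydrogen-bond acceptor, while the six-membered aromatic ring remains, so a small edit on this nitrogen is enough for a large step. Nothing available explains why the number falls. The compounds shown leave open whether an acetyl group, which keeps the carbonyl without the aromatic ring, would stay near compound 3. They also leave open whether a phenylsulfonyl group on this nitrogen would do so.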